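The source may hold more compounds than are shown below. What is called first, only, known or untested is meant among the compounds shown, and "the series" means these compounds.

Compound 1 `Cc1cc(-n2cccc2)cn2c(CSCCc3ccccc3)cnc12` is measured in an ADME assay on HEL cells (Homo sapiens) for cytotoxicity, with a stated time of 3 days; a higher number here means that more compound is tolerated, a lower number that less compound is tolerated. For compound 1 the value >= 4 ug/mL is a limit of the assay, not a number. Compound 2 `Cc1cc(-n2cccc2)cn2c(CSCc3ccccc3)cnc12` gives 20 ug/mL in this assay. The change between them, (phenyl in place of benzyl on a saturated chain carbon bound to a sulfur), made a step that the limit leaves unreadable from compound 1 to compound 2, which stays unreadable because of the limit of >= 4 ug/mL in this assay, at which 1 of the 3 values shown sits. Compound 3 `Cc1cc(-n2cccc2)c2ncc(CSCCc3ccccc3)n2c1` gives 100 ug/mL in this assay, the highest of the two numbers, with its gap to compound 2 beyond the scatter. The difference between the core of compound 3 and the core of compound 1 is not broken down here. Compound 4 `Cc1cc(-n2cccc2)c2ncc(CSCc3ccccc3)n2c1` is not yet measured; it carries the same change as before, (phenyl in place of benzyl on a saturated chain carbon bound to a sulfur). Since the earlier step is unreadable, the expectation for compound 4 rests on compound 3 and 100 ug/mL alone, and the step is estimated as a 1.3-fold lower number from compound 3 to compound 4 (0.10 log units; within the scatter). Compound 4 is therefore expected near 80 ug/mL, between 25 ug/mL and 200 ug/mL.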

Compound 4, minimum cytotoxic concentration: 100 ug/mL
The estimate for compound 4 lay 1.3-fold (0.10 log units) below the measured number; low and high end bracket the measured number.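

On the core of compound 3, putting phenyl in place of benzyl on a saturated chain carbon bound to a sulfur gave no change at the digits printed from compound 3 to compound 4 (within the scatter) in this assay. Compound 1 carries a limit and not a number, so its step to compound 2 cannot be read: the limit of >= 4 ug/mL in this assay, at which 1 of the 4 values shown sits. The result therefore stands for one core only, and it neither confirms nor rules out that the change behaves alike on the core of compound 1.

The compounds shown leave open how a longer chain, such as phenylpropyl, would read in this assay at this place. They also leave open whether an amine or a carboxylic acid on the phenyl ring would shift the number.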